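A smaller aryl ether and its expected tolerance

The source may report more compounds than this note shows. Statements on the series, on what has been measured and on what is new or still open speak of the compounds shown alone.

Measured so far:
compound 1 `COc1cc(C#N)ccc1Oc1nc(Nc2ccc(C#N)cc2)nc2ccccc12` – >= 140000 nM
compound 2 `COc1cc(C#N)cc(Cl)c1Oc1nc(Nc2ccc(C#N)cc2)nc2ccccc12` – 220000 nM
compound 3 `CCCOc1cc(C#N)cc(OC)c1Oc1nc(Nc2ccc(C#N)cc2)nc2ccccc12` – 5200 nM

In an ADME assay on MT4 cells (Homo sapiens) for cytotoxicity, read by MTT assay, with a stated time of 4 days (a lower number here means that less compound is tolerated, a higher number that more compound is tolerated), compound 1 gives only a limit, >= 140000 nM, with no number behind it (the limit of >= 140000 nM in this assay, at which 1 of the 3 values shown sits). Compound 2 gives 220000 nM, and compound 3 gives 5200 nM. Compound 4 `Cc1ccc(Oc2nc(Nc3ccc(C#N)cc3)nc3ccccc23)cc1` differs from compound 1 by 4-methylphenyl in place of 4-cyano-2-methoxyphenyl on an oxygen on an aromatic ring. The measured steps add groups to the ring that leaves: a step that the limit leaves unreadable from compound 1 to compound 2, an at least 26-fold lower number from compound 1 to compound 3 (1.43 log units; beyond the scatter) and a 42-fold lower number from compound 2 to compound 3 (1.63 log units; beyond the scatter). None of them removes the cyano or methoxy, so they bear only loosely on compound 4. Compound 4 is expected to stay near compound 1, a step of an at least 1.1-fold lower number from compound 1 to compound 4 (0.06 log units; that floor lies within the scatter), with no direction beyond the scatter. Compound 4 is estimated at 120000 nM, between 25000 nM and 300000 nM.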

Compound 4, half-maximal cytotoxic concentration: 87000 nM
Beside the measured number, compound 4's estimate is 1.4-fold (0.14 log units) above it, within the range that was stated.
By their numbers in this assay, from the lowest: compound 3; then compound 4; then compound 2.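

In this assay, 4-methylphenyl in place of 4-cyano-2-methoxyphenyl on an oxygen on an aromatic ring gives an at least 1.6-fold lower number from compound 1 to compound 4 (0.20 log units; that floor lies within the scatter). The earlier compounds shown here all kept the cyano and methoxy groups, whereas here both go at once, and the floor of the step shows no loss of tolerance beyond the scatter. Compound 1 gives a limit, >= 140000 nM, and not a number: the limit of >= 140000 nM in this assay, at which 1 of the 4 values shown sits.

The compounds shown leave open what the cyano or the methoxy group does alone. They also leave open how an amine or a carboxylic acid in place of the methyl group would read in this assay.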